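The source may report more compounds than this note shows. Statements on the series, on what has been measured and on what is new or still open speak of the compounds shown alone.

Compound 1 `COc1cc(/C=C/C(=O)c2cccc(-n3cc(-c4ccccc4)[nH]c3=O)c2)ccc1O` is one of three compounds examined in a functional assay on EKVX cells (Homo sapiens) for inhibition (a higher number here means a weaker inhibitor of growth, a lower number a stronger inhibitor of growth), where compound 1 gives 3900 nM. Compound 2 `COc1cc(/C=C/C(=O)c2cccc(-n3cc(-c4ccccc4)[nH]c3=O)c2)cc(OC)c1OC` gives 2300 nM in this assay, and compound 3 `COc1cc(/C=C/C(=O)c2cccc(-n3cc(-c4cc(OC)c(OC)c(OC)c4)[nH]c3=O)c2)cc(OC)c1OC` gives 9470 nM. Compound 1 therefore stands second highest of the three, with compound 2 within the scatter of it and compound 3 beyond it. Within the data shown here, the only single-point change among the measured compounds is a 4.1-fold higher number from compound 2 to compound 3 (0.61 log units; beyond the scatter), a modest step in which the phenyl on the shared core carries three methoxy groups.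

Compound 4 `COc1cc(/C=C/C(=O)c2cccc(-n3cc(-c4ccc(Cl)cc4)[nH]c3=O)c2)ccc1O` differs from compound 1 by chloro in place of hydrogen on an aromatic carbon, so that the phenyl becomes 4-chlorophenyl. Among the measured compounds shown here, no measured step shows chloro in place of hydrogen, and the step from compound 2 to compound 3 concerns a different substitution of the same phenyl, so it bears on compound 4 only loosely. Since the methoxy change on this phenyl moved this assay only modestly, the single chloro is expected to give no step beyond the scatter, a 1.1-fold lower number from compound 1 to compound 4 (0.05 log units; within the scatter). Compound 4 is therefore estimated at 3500 nM, with a range from 1200 nM to 10000 nM.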

Compound 4, concentration for 50% growth inhibition: 9610 nM
For compound 4 the middle estimate is 2.7-fold (0.44 log units) below the measured one, and the stated range covers the measured number.
By their numbers in this assay, from the lowest: compounds 2 and 1 (each within the scatter of the next); then compounds 3 and 4 (each within the scatter of the next).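

In this assay a lone chloro, para to a large group on the phenyl, is enough to give a 2.5-fold higher number from compound 1 to compound 4 (0.39 log units; beyond the scatter), so even one small substituent at this place moves the number beyond the scatter. Until now the only change shown on this phenyl was the larger replacement in a 4.1-fold higher number from compound 2 to compound 3 (0.61 log units; beyond the scatter), and the two steps now point the same way, towards a weaker inhibitor of growth, although they stand on two different compounds and neither goes against the other. Nothing measured here accounts for this shared direction, and the data give no explanation for the chloro step.

As far as these compounds go, what stays open is whether the higher number belongs to chloro itself or would follow any group at this place, which a lone fluoro, a lone methoxy, an amine or a carboxylic acid on the phenyl could separate. From the compounds shown here alone, it also remains open whether chloro would give a step of similar size on the core of compound 2, or whether its effect depends on the rest of the molecule.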